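The source may hold more compounds than are shown below. What is called first, only, known or untested is meant among the compounds shown, and "the series" means these compounds.

Measured compounds:
- compound 1, `O=C(CBr)Nc1ccc(C(=O)/C=C/c2ccco2)cc1`: 33%
- compound 2, `CC(O[N+](=O)[O-])C(=O)Nc1ccc(C(=O)/C=C/c2ccc(Cl)cc2)cc1`: 61%
- compound 3, `COc1ccc(/C=C/C(=O)c2ccc(NC(=O)C(C)O[N+](=O)[O-])cc2)cc1`: 43%

All three were tested in a functional assay on the whole organism (strain albino) for inhibition, with Rattus norvegicus as the target, read by paw edema, with stated times of 30 min and 4 h, at a dose of 100 mg/kg by the oral route; a higher number here means more inhibition at the dose given (going by the name of the read-out), a lower number less inhibition. On these numbers compound 3 stands second highest of the three. Its nearest neighbour is compound 1, whose value lies within the scatter of that of compound 3, so the two cannot be told apart. Going by the values given here, compound 2 stands further off, and the one change that turns compound 2 into compound 3 gives a number 18 percentage points lower from compound 2 to compound 3 (beyond the scatter).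

Compound 4, `CC(O[N+](=O)[O-])C(=O)Nc1ccc(C(=O)/C=C/c2ccco2)cc1`, has not yet been measured in this assay. It differs from compound 3 in one place: furan-2-yl in place of 4-methoxyphenyl on a double-bonded chain carbon bound to a double-bonded chain carbon. Among the compounds with values here, no measured pair shows exactly this change on an otherwise identical core; the only measured step, from compound 2 to compound 3, concerns a different group. Compound 1 carries the same furan-2-yl group as compound 4 but differs in the amide part, and its value sits within the scatter of compound 3. There is therefore no basis for expecting a step beyond the scatter in this assay; a step of a number 5 percentage points lower from compound 3 to compound 4 (within the scatter) is estimated. For compound 4 the expected value is 38%, with a range from 24% to 52%.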

Compound 4, a percentage reported as inhibition, in the whole organism at one dose (the size of the read-out at that dose, not a potency): 49%
The estimate for compound 4 lay 11 percentage points below the measured number; measured number inside the range.
By their numbers in this assay, from the lowest: compounds 1, 3 and 4 (each within the scatter of the next, the first and the last beyond it); then compound 2.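

In this assay, furan-2-yl in place of 4-methoxyphenyl on a double-bonded chain carbon bound to a double-bonded chain carbon gives a number 6 percentage points higher from compound 3 to compound 4 (within the scatter), so a five-membered aromatic ring with one hetero atom and this six-membered aromatic ring cannot be told apart at this place. Set against 4-chlorophenyl, the same furan-2-yl gives a number 12 percentage points lower from compound 2 to compound 4 (beyond the scatter), so compound 2 now stands clear of both other groups tested on this nitrooxy-bearing core, not only of the 4-methoxyphenyl compound. Going by these compounds alone, with furan-2-yl held fixed, 1-(nitrooxy)ethyl in place of bromomethyl on a carbonyl carbon gives a number 16 percentage points higher from compound 1 to compound 4 (beyond the scatter), which shows for the first time that the number also responds to a change in this second place on the molecule.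

No measurement offered here explains any of these steps. On these data alone, it remains open whether a thiophene ring or an unsubstituted phenyl ring on the same chain carbon would stay level with compound 2 or with compound 4, and whether an aminomethyl group on the carbonyl carbon would retain the number of compound 4.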